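The source may hold more compounds than are shown below. What is called first, only, known or untested is meant among the compounds shown, and "the series" means these compounds.

Series notes. The shared core of compound 1 `Nc1nc(Cl)nc(Nc2ccc(N3CCOCC3=O)cc2)n1` carries an amino group on one aromatic carbon; in a functional assay on the whole organism (strain Swiss) for inhibition, with Mus musculus as the target, with a stated time of 30 min, at a dose of 10 mg/kg by the intraperitoneal route (a lower number here means a weaker effect, a higher number a stronger effect of the compound at the dose given), compound 1 gives 74%. Compound 2 `O=C1COCCN1c1ccc(Nc2nc(Cl)nc(N3CCCC3)n2)cc1` has pyrrolidin-1-yl in that place and in this assay compound 2 gives 93%. Compound 3 `O=C1COCCN1c1ccc(Nc2nc(Cl)nc(Nc3ccc(Cl)cc3)n2)cc1` carries (4-chlorophenyl)amino there; in this assay compound 3 gives 90.2%, the second highest of the three numbers. The step of a number 16.2 percentage points higher from compound 1 to compound 3 (beyond the scatter) is beyond the scatter, while a number 2.8 percentage points lower from compound 2 to compound 3 (within the scatter) lies within it, so compound 2 and compound 3 cannot be ordered against each other.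

Compound 4 `COc1ccc(Nc2nc(Cl)nc(Nc3ccc(N4CCOCC4=O)cc3)n2)cc1` differs from compound 3 by methoxy in place of chloro on an aromatic carbon. For the measured compounds named here, no measured pair in this set alters a substituent on the 4-chlorophenyl group itself; the measured steps concern what sits on the aromatic carbon of the core. Both a number 19 percentage points higher from compound 1 to compound 2 (beyond the scatter) and a number 16.2 percentage points higher from compound 1 to compound 3 (beyond the scatter) show a modest rise when amino is replaced by a larger group, and a number 2.8 percentage points lower from compound 2 to compound 3 (within the scatter) shows that exchanging one such larger group for another stayed within the scatter. Methoxy in place of chloro keeps a substituted phenyl amino group on that carbon, so in this assay the expected step for compound 4 is a number 4.2 percentage points lower from compound 3 to compound 4 (within the scatter), none beyond the scatter. Compound 4 is estimated at 86%, with a range from 66% to 100%.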

Compound 4, a percentage reported as inhibition, in the whole organism at one dose (the size of the read-out at that dose, not a potency): 79%
Compound 4: middle estimate off by 7 percentage points, on the high side; the range from low to high includes it.
By their numbers in this assay, from the lowest: compounds 1 and 4 (each within the scatter of the next); then compounds 3 and 2 (each within the scatter of the next).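

For the compounds shown here, the group para to a large group on the phenyl ring now proves to count: in this assay the change of chloro to methoxy gives a number 11.2 percentage points lower from compound 3 to compound 4 (beyond the scatter) and thus a real change, which the earlier steps at the core carbon could not show. A substituted phenylamino group therefore does not by itself hold the level of pyrrolidin-1-yl, as (4-methoxyphenyl)amino in place of that ring gives a number 14 percentage points lower from compound 2 to compound 4 (beyond the scatter) whereas the (4-chlorophenyl)amino group stayed within the scatter of it. The rise over the amino group is also not general to larger groups: 4-methoxyphenyl in place of hydrogen on the nitrogen gives only a number 5 percentage points higher from compound 1 to compound 4 (within the scatter) and so cannot be told apart from the amino compound, unlike the 4-chlorophenyl and pyrrolidin-1-yl cases. Nothing available accounts for the difference between chloro and methoxy.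

Going by these compounds, whether the chloro level reflects something particular to that atom remains open, and a fluoro, a methyl or a carboxylic acid at the same place would test this. Also open, on these data alone, is whether a larger saturated amine on the core carbon, such as piperidin-1-yl or morpholin-4-yl, would keep the level of pyrrolidin-1-yl.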